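The source may hold more compounds than are shown below. What is called first, only, known or untested is meant among the compounds shown, and "the series" means these compounds.

Measured compounds:

Compound 1, `COc1ncc(-c2ccc3c(c2)N(CCC(=O)N2CCOCC2)C(=O)CO3)cc1NS(=O)(=O)c1ccc(F)cc1F`, in a functional assay on MDA-MB-231 cells (Homo sapiens) for antiproliferative activity, read by sulforhodamine B assay, with a stated time of 72 h (on this read-out lower numbers stand for stronger inhibition and higher numbers for weaker inhibition), compound 1 gives 3260 nM.
Compound 2, `COc1ncc(-c2ccc3c(c2)N(CCCn2ccccc2=O)C(=O)CO3)cc1NS(=O)(=O)c1ccc(F)cc1F`, in this assay compound 2 gives 12400 nM.
Compound 3, `CCCCS(=O)(=O)Nc1cc(-c2ccc3c(c2)N(CCC(=O)N2CCOCC2)C(=O)CO3)cnc1OC`, in this assay compound 3 gives 43800 nM.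

Compound 4, `CCCCS(=O)(=O)Nc1cc(-c2ccc3c(c2)N(CCCn2ccccc2=O)C(=O)CO3)cnc1OC`, has not yet been measured in this assay.

The change from compound 1 to compound 2 is a group of 8 heavy atoms (6 carbon, 1 nitrogen, 1 oxygen; one six-membered aromatic ring with 1 hetero atom) in place of a group of 8 heavy atoms (5 carbon, 1 nitrogen, 2 oxygen; one six-membered non-aromatic ring with 2 hetero atoms), on a saturated chain carbon, two bonds along the chain from an amide-type nitrogen in a ring. In this assay it gave a 3.8-fold higher number from compound 1 to compound 2 (0.58 log units; beyond the scatter). The same change, in the same place, carries compound 3 to compound 4: a group of 8 heavy atoms (6 carbon, 1 nitrogen, 1 oxygen; one six-membered aromatic ring with 1 hetero atom) in place of a group of 8 heavy atoms (5 carbon, 1 nitrogen, 2 oxygen; one six-membered non-aromatic ring with 2 hetero atoms), on a saturated chain carbon, two bonds along the chain from an amide-type nitrogen in a ring.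

The cores of compound 1 and compound 3 differ by butyl in place of 2,4-difluorophenyl on a sulfonyl sulfur, and in this assay that difference gave a 13-fold higher number from compound 1 to compound 3 (1.13 log units; beyond the scatter). Compound 3 therefore stands highest of the three measured numbers, and compound 4 starts from that point.

For the measured compounds named here, with only one earlier example of the change, the expectation for compound 4 rests on the step of a 3.8-fold higher number from compound 1 to compound 2 (0.58 log units; beyond the scatter) being repeated on the core of compound 3, and on compound 3 already giving 43800 nM. It is expected that compound 4 shows a weaker result than compound 3, with an estimated step of a 3.0-fold higher number from compound 3 to compound 4 (0.47 log units; beyond the scatter) in this assay. The estimate for compound 4 in this assay is 130000 nM, expected to fall between 40000 nM and 350000 nM, with a real chance that so high a number is reported only as a limit of the assay.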

Compound 4, half-maximal inhibitory concentration: 47900 nM
For compound 4 the middle estimate is 2.7-fold (0.43 log units) above the measured one; the measured number falls inside the stated range.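

On the butyl core, the exchange of the (morpholin-4-yl)carbonyl group for the group bearing the six-membered aromatic ring with 1 hetero atom gave a 1.1-fold higher number from compound 3 to compound 4 (0.04 log units; within the scatter) in this assay, so the step seen on the 2,4-difluorophenyl core did not carry over in size: the same change on two cores in this assay, a 3.8-fold higher number (0.58 log units; beyond the scatter) from compound 1 to compound 2 and a 1.1-fold higher number (0.04 log units; within the scatter) from compound 3 to compound 4, 3.5-fold (0.54 log units) apart, beyond the scatter of two such steps. Read the other way, butyl in place of 2,4-difluorophenyl on the sulfonyl sulfur gave a 3.9-fold higher number from compound 2 to compound 4 (0.59 log units; beyond the scatter), the same direction as on the morpholine-bearing core but a smaller step: the same change on two cores in this assay, a 13-fold higher number (1.13 log units; beyond the scatter) from compound 1 to compound 3 and a 3.9-fold higher number (0.59 log units; beyond the scatter) from compound 2 to compound 4, 3.5-fold (0.54 log units) apart, beyond the scatter of two such steps. For the compounds shown here, this shows that in these four compounds the two changes do not add up independently, so a step measured on one core cannot simply be transferred to the other, but with only two cores it gives no general rule for the series and does not show why the steps differ.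

The compounds shown leave open how the exchange behaves with other groups on the sulfonyl sulfur, such as a phenyl without fluorine or a shorter alkyl chain. They also leave open whether a piperazine amide or a carboxylic acid at the end of the chain would follow the morpholine or the aromatic ring group on either core.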